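This account rests on a few compounds, and the source may have more. Where it says the series, first, only, none or still open, it means among the compounds named here.

Measured compounds:
compound 1 `CCCSc1nc(N/N=C(\C)c2ccccc2O)c2nnn(Cc3ccco3)c2n1` — 29000 nM in a functional assay on MCF7 cells (Homo sapiens) for antiproliferative activity, read by MTT assay, with a stated time of 72 h; a higher number here means a weaker inhibitor, a lower number a stronger inhibitor
compound 2 `COc1cc(/C=N/Nc2nc(SCc3ccccc3)nc3c2nnn3Cc2ccccc2)cc(OC)c1OC` — 13500 nM

Compound 1 gives the highest number of the two; compound 2 gives a lower number, and the gap between them lies beyond the scatter, so compound 1 is the weaker inhibitor here. The next compound, compound 3 `CCCSc1nc(N/N=C(\C)c2ccccc2O)c2nnn(Cc3ccccc3)c2n1`, is unmeasured. It differs from compound 1 in one place: phenyl in place of furan-2-yl on a saturated chain carbon bound to an aromatic nitrogen. Within the data shown here, no measured pair shows this change, so the expectation rests on compound 1 alone. A step of a 1.3-fold lower number from compound 1 to compound 3 (0.12 log units; within the scatter) is expected, not beyond the scatter in either direction. Compound 3 is estimated at 22000 nM, with a range from 8000 nM to 60000 nM.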

Compound 3, half-maximal inhibitory concentration: 11000 nM
Compound 3: the middle estimate sits 2.0-fold (0.30 log units) above what was measured, within the range that was stated.
By their numbers in this assay, from the lowest: compounds 3 and 2 (each within the scatter of the next); then compound 1.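

The group on the saturated chain carbon bound to an aromatic nitrogen affects the read-out in this assay, since phenyl in place of furan-2-yl gives a 2.6-fold lower number from compound 1 to compound 3 (0.42 log units; beyond the scatter) with the rest of compound 1 unchanged. Among these compounds, this is the first single-place comparison, and its step is modest. Nothing on hand explains this step.

On these data alone, it remains open whether a pyridine ring, a cyclohexyl group or an amine at this place would match phenyl. As far as these compounds go, whether the step carries over to other groups on the shared core also remains open.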